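A few compounds are considered here, and "the series" means these few. Any claim that something is new, unique, unknown or untested is made for them only; others in the source may bear on it.

Among the measured compounds shown here, compound 2 `CC(C)c1cccc(C(C)C)c1NC(=O)NCC1(c2cccc(N(C)C)c2)CCCC1` gives 33 nM in an assay on microsomes for inhibition of acyl-CoA:cholesterol acyltransferase (Oryctolagus cuniculus) (on this read-out lower numbers stand for stronger inhibition and higher numbers for weaker inhibition), the highest of the two numbers measured so far; its nearest neighbour is compound 1 `COc1cccc(C2(CNC(=O)Nc3c(C(C)C)cccc3C(C)C)CCCC2)c1`, which in this assay gives 13 nM. For the measured compounds named here, the single measured step between them, a 2.5-fold higher number from compound 1 to compound 2 (0.40 log units; beyond the scatter), is a modest one and arises from dimethylamino in place of methoxy on an aromatic carbon. Compound 3 `CC(C)c1cccc(C(C)C)c1NC(=O)NCC1(c2ccc(C(=O)O)cc2)CCCC1` has not yet been measured. It differs from compound 2 by 4-carboxyphenyl in place of 3-(dimethylamino)phenyl on a saturated ring carbon. Going by the values given here, no measured step covers an exchange of the whole aryl group attached to the saturated ring carbon; the one step known shows only that altering the substituent on that aromatic ring shifts the number modestly, and that a more weakly active compound sits at the end of that change. On this thin basis a further weakening is expected rather than a gain, with wide uncertainty. Compound 3 is therefore estimated to give 150 nM in this assay, within a range of 30 nM to 800 nM, which corresponds to an expected step of a 4.5-fold higher number from compound 2 to compound 3 (0.66 log units; beyond the scatter).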

Compound 3, half-maximal inhibitory concentration: 3100 nM
Compound 3: the middle estimate sits 21-fold (1.32 log units) below what was measured; the whole stated range lies below it.
By their numbers in this assay, from the lowest: compound 1; then compound 2; then compound 3.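

In this assay, the exchange of the whole aryl group on the saturated ring carbon gives a 94-fold higher number from compound 2 to compound 3 (1.97 log units; beyond the scatter) and, set against the methoxy compound, a 240-fold higher number from compound 1 to compound 3 (2.38 log units; beyond the scatter) as well. Both steps are large, while the earlier change on the aromatic ring gave only a 2.5-fold higher number from compound 1 to compound 2 (0.40 log units; beyond the scatter) and was modest, so this position clearly does not accept every aryl group alike: 3-methoxyphenyl and 3-(dimethylamino)phenyl stay close to each other, and 4-carboxyphenyl stands far from both. No supporting measurement bears on why the number rises so far.

The exchange alters the substituent and its place on the aromatic ring in one move, which leaves open whether the carboxylic acid itself or its attachment in the 4-carboxyphenyl arrangement accounts for the large step. Also open, on these data alone, is whether a methyl ester, a primary amide or a hydroxymethyl group carried in the same place would stay as far from compound 1 as compound 3 does, or would return towards it.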